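Adding a chloro group to a hydroxyphenyl amide

The source may report more compounds than this note shows. Statements on the series, on what has been measured and on what is new or still open speak of the compounds shown alone.

In a functional assay on SK-BR-3 cells (Homo sapiens) for antiproliferative activity (on this read-out lower numbers stand for stronger inhibition and higher numbers for weaker inhibition), compound 1 `Cc1c(OC2CCN(C)CC2)ccc2cc(NC(=O)c3ccc(O)c(CCC(C)C)c3)c(=O)oc12` gives 600 nM, compound 2 `CC(C)=CCc1cccc(C(=O)Nc2cc3ccc(OC4CCN(C)CC4)c(C)c3oc2=O)c1` gives 1680 nM, and compound 3 `Cc1c(OC2CCN(C)CC2)ccc2cc(NC(=O)c3ccc(O)cc3)c(=O)oc12` gives 840 nM. The number for compound 3 lies between the other two, and its gap to each of them stays within the usual scatter of repeated measurements.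

Compound 4 `Cc1c(OC2CCN(C)CC2)ccc2cc(NC(=O)c3ccc(O)c(Cl)c3)c(=O)oc12` differs from compound 3 in one place: chloro in place of hydrogen on an aromatic carbon. Chloro takes the place of a hydrogen on an aromatic carbon, ortho to a hydroxy group.

Two measured steps offer some guidance. The closer one is a 1.4-fold higher number from compound 1 to compound 3 (0.15 log units; within the scatter), where hydrogen replaces isopentyl on an aromatic carbon. The other is a 2.0-fold lower number from compound 2 to compound 3 (0.30 log units; within the scatter), where 4-hydroxyphenyl replaces 3-(3-methylbut-2-en-1-yl)phenyl on a carbonyl carbon. Both steps lie within the scatter, so these compounds give no sign of a large response to changes on this part of the molecule. None of them carries a chloro group, however, so the data do not show what chloro itself does, and the range must stay wide.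

The expected size of the step is small, no larger than the scatter: a 1.2-fold lower number from compound 3 to compound 4 (0.08 log units; within the scatter). Compound 4 is estimated at 700 nM, with an expected range of 300 nM to 1600 nM.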

Compound 4, half-maximal inhibitory concentration: 2300 nM
Estimate against measurement, compound 4: 3.3-fold (0.52 log units) below; measured number outside the range, above it.
By their numbers in this assay, from the lowest: compounds 1, 3, 2 and 4 (each within the scatter of the next, the first and the last beyond it).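

Chloro in place of hydrogen on this ring, ortho to a hydroxy group, gives a 2.7-fold higher number from compound 3 to compound 4 (0.44 log units; beyond the scatter) in this assay, which shows that this position can respond to a change of just one heavy atom, a step beyond the scatter that the earlier compounds did not show here. The same position also carries isopentyl, and putting chloro there instead gives a 3.8-fold higher number from compound 1 to compound 4 (0.58 log units; beyond the scatter) on the same read-out, so among these compounds hydrogen and isopentyl sit within the scatter of each other while chloro moves away from both, and size alone does not order the three groups. Exchanging the 3-(3-methylbut-2-en-1-yl)phenyl group for 3-chloro-4-hydroxyphenyl gives a 1.4-fold higher number from compound 2 to compound 4 (0.14 log units; within the scatter) and stays within the scatter, so the chloro compound cannot be told apart from that amide.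

Going by these compounds, whether a fluoro or methoxy group, an amine or a longer chain at this position would follow chloro or isopentyl remains open. No measurement among these compounds speaks to why chloro raises the number here.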